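The source may report more compounds than this note shows. Statements on the series, on what has been measured and on what is new or still open speak of the compounds shown alone.

Series notes: in a functional assay on KBVIN cells (Homo sapiens) for antiproliferative activity, read by sulforhodamine B assay, with a stated time of 3 days (on this read-out lower numbers stand for an effect already at smaller amounts and higher numbers for an effect only at larger amounts of compound), compound 1 (`CCOc1ccc(-c2cc(=O)c3c(o2)C(CC)(CC)C(=O)C(CC)=C3O)cc1`) gives 7.54 uM on the shared core. Compound 2 (`CCC1=C(O)c2c(oc(-c3ccc(C)cc3C)cc2=O)C(CC)(CC)C1=O`) gives 8.52 uM and so stands level with compound 1 within the scatter. The change to compound 3 (`CCC1=C(O)c2c(oc(-c3ccc(OC)c(C)c3)cc2=O)C(CC)(CC)C1=O`) puts 4-methoxy-3-methylphenyl in place of 2,4-dimethylphenyl on an aromatic carbon next to the ring oxygen (4-methoxy-3-methylphenyl in place of 2,4-dimethylphenyl on an aromatic carbon) and leaves the rest of the core untouched. Among the compounds with values here, the one measured step at this place replaced 4-ethoxyphenyl with 2,4-dimethylphenyl and gave a 1.1-fold higher number from compound 1 to compound 2 (0.05 log units; within the scatter) which stays within the scatter. That single step is thin evidence, yet it points to no shift beyond the scatter in this assay for the new exchange. The expected change is a 1.1-fold lower number from compound 2 to compound 3 (0.06 log units; within the scatter) and no direction can be argued from the data. Compound 3 is estimated at 7.5 uM with an expected range from 3 uM to 16 uM overall.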

Compound 3, concentration for half-maximal effect: 0.1 uM
The estimate for compound 3 lay 75-fold (1.88 log units) above the measured number; measured number outside the range, below it.
By their numbers in this assay, from the lowest: compound 3; then compounds 1 and 2 (each within the scatter of the next).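

In this assay, the aryl group on the aromatic carbon next to the ring oxygen proves far from neutral: 4-methoxy-3-methylphenyl in place of 2,4-dimethylphenyl gives an 85-fold lower number from compound 2 to compound 3 (1.93 log units; beyond the scatter), and the same group in place of 4-ethoxyphenyl gives a 75-fold lower number from compound 1 to compound 3 (1.88 log units; beyond the scatter). The earlier exchange between 4-ethoxyphenyl and 2,4-dimethylphenyl stayed within the scatter, so that level result did not carry over to a third aryl group, and the position responds strongly to the choice of substituents on this ring. No supporting measurement is at hand to explain the size of these steps.

The compounds shown leave open whether the methoxy, the methyl or their combination carries the effect. Also open, from the compounds shown here alone, is how an amine or a carboxylic acid in place of that methoxy would read out here.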